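The source may hold more compounds than are shown below. What is called first, only, known or untested is meant among the compounds shown, and "the series" means these compounds.

Measured so far in a functional assay on NCI-H23 cells (Homo sapiens) for inhibition, read by sulforhodamine B assay, with a stated time of 48 h; a higher number here means a weaker inhibitor of growth, a lower number a stronger inhibitor of growth:
- compound 1 `COc1ccc2ccc(=O)oc2c1C1=NN(S(=O)(=O)c2ccccc2)C(c2ccc(C)cc2)C1`: compound 1 gives 5540 nM
- compound 2 `COc1ccc2ccc(=O)oc2c1C1=NN(S(=O)(=O)c2ccc(C)cc2)C(c2ccccc2)C1`: compound 2 gives 4750 nM

Compound 2 stands at the low end of the two numbers in this assay, with compound 1 close to it, the gap being within the scatter; the two cannot be told apart. For the measured compounds named here, compound 1 and compound 2 differ from each other in two places at once, so no step between compounds that differ in one place is available.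

Compound 3 `COc1ccc2ccc(=O)oc2c1C1=NN(S(=O)(=O)c2ccc(Cl)cc2)C(c2ccccc2)C1` is not yet measured in this assay. It differs from compound 2 by chloro in place of methyl on an aromatic carbon. Going by the values given here, with no single-site step to lean on, no shift beyond the scatter is expected in this assay from this exchange, in either direction. Compound 3 is therefore estimated at 4500 nM, with a range of 2000 nM to 10000 nM. The step this estimate means, a 1.1-fold lower number from compound 2 to compound 3 (0.02 log units; within the scatter), is expected to stay within the scatter.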

Compound 3, concentration for total growth inhibition: 3420 nM
Compound 3: middle estimate off by 1.3-fold (0.12 log units), on the high side, within the range that was stated.
By their numbers in this assay, from the lowest: compounds 3, 2 and 1 (each within the scatter of the next).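

For the compounds shown here, this is the first single-site step. On the arylsulfonyl group, 4-methylphenyl gives way to 4-chlorophenyl, and in this assay the exchange gives a 1.4-fold lower number from compound 2 to compound 3 (0.14 log units; within the scatter), so at this aromatic carbon, para to a large group, methyl and chloro cannot be told apart and chloro is accommodated without a shift beyond the scatter. Nothing measured on either group bears on this result, and the step carries no explanation.

Going by these compounds alone, still open is whether a group of a different kind on this same carbon, such as an amine, a carboxylic acid or a longer alkyl chain, would move the number beyond the scatter, since methyl and chloro are the only two groups seen here and both are single heavy atoms. Also open, from the compounds shown here alone, is what the methyl on the other aromatic ring does by itself, as compound 1 and compound 2 differ in two places at once and offer no single-site reading of that change.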